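The source may report more compounds than this note shows. Statements on the series, on what has been measured and on what is new or still open speak of the compounds shown alone.

Measured so far:
- compound 1, `Cc1nn([C@H](C)c2ccc(Cl)cc2Cl)c2nc(N3CC[C@H](N4CCC4)[C@H](C)C3)cnc12`: 58 nM
- compound 2, `Cc1nn(C(C)c2ccc(Cl)cc2Cl)c2nc(N3CCC(N4CCCCC4)C(C)C3)cnc12`: 126 nM

Working notes on the series. For the measured compounds named here, in a functional assay on cells for antagonist activity at C-C chemokine receptor type 4 (Homo sapiens), read by fluorescence and calcium flux, with stated times of 2.5 s and 45 s (a higher number here means a weaker inhibitor, a lower number a stronger inhibitor), compound 1 gives 58 nM, the lowest of the two numbers so far. In this assay compound 2 gives 126 nM, a higher number than compound 1 and beyond the scatter of repeated runs; the two compounds differ in the ring attached to the saturated ring carbon and in whether the stereocentres are defined, so no single-point comparison is drawn from them.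

Compound 3, `Cc1nn([C@H](C)c2ccc(Cl)cc2Cl)c2nc(N3CC[C@H](N4CCC[C@H]4CCC#N)[C@H](C)C3)cnc12`, is not yet measured in this assay. It is obtained from compound 1 by the change (2-(2-cyanoethyl)pyrrolidin-1-yl in place of azetidin-1-yl on a saturated ring carbon). The entering group brings a second hydrogen-bond acceptor in the nitrile and a defined stereocentre on the five-membered ring, and it is larger than what it replaces.

With no measured step of this kind in hand, the expectation rests on compound 1 at 58 nM and on compound 2 at 126 nM showing that a larger saturated ring in this place was tolerated with only a modest loss. The step of a 1.6-fold higher number from compound 1 to compound 3 (0.19 log units; within the scatter) is expected to be small, leaning toward a weaker inhibitor, and within or just beyond the scatter. Compound 3 is estimated at 90 nM, with a range from 30 nM to 300 nM.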

Compound 3, half-maximal inhibitory concentration: 41 nM
The estimate for compound 3 lay 2.2-fold (0.34 log units) above the measured number; low and high end bracket the measured number.
By their numbers in this assay, from the lowest: compounds 3 and 1 (each within the scatter of the next); then compound 2.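

In this assay, for the compounds shown here, putting 2-(2-cyanoethyl)pyrrolidin-1-yl in place of azetidin-1-yl on the saturated ring carbon gives a 1.4-fold lower number from compound 1 to compound 3 (0.15 log units; within the scatter), the first step that differs in one place. It shows that this position accepts a much larger group, a five-membered ring with a cyanoethyl chain and a defined stereocentre, with no change beyond the scatter, so the small azetidin-1-yl is not required for a number of this size. No measurement at hand accounts for this result.

The compounds shown leave open whether the pyrrolidine ring or the cyanoethyl chain matters more here, as both enter together in one change, and a plain pyrrolidin-1-yl would separate the two. Also open, going by these compounds, are how far the chain can be varied at this place, for instance with a primary amine or a carboxylic acid in place of the nitrile or with a longer chain, and how the opposite configuration at the new stereocentre reads in this assay.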